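Swapping 2-hydroxyphenyl for 3-chlorophenyl

The source may report more compounds than this note shows. Statements on the series, on what has been measured and on what is new or still open speak of the compounds shown alone.

In a physicochemical assay for lipophilicity, measured as octanol-water partition (on this read-out higher numbers stand for higher lipophilicity and lower numbers for lower lipophilicity), compound 1 `O=C(COc1cccc2ccccc12)N/N=C/c1cccc(O)c1` reads 3.73 and compound 2 `O=C(COc1cccc2ccccc12)N/N=C/c1ccccc1O` stands level with it at 3.73 at the digits shown. Compound 3 `O=C(COc1cccc2ccccc12)N/N=C/c1cccc(Cl)c1` carries 3-chlorophenyl in place of 2-hydroxyphenyl on a carbon with a double bond to nitrogen. Among the compounds with values here, the only measured step (no change at the digits printed from compound 1 to compound 2 (within the scatter)) stayed within the scatter and merely exchanged 3-hydroxyphenyl for 2-hydroxyphenyl, so it gives no direct measure of this swap. From the structural change alone, an upward step beyond the scatter is expected, estimated as (a number 0.67 log units higher from compound 2 to compound 3 (beyond the scatter)). The estimated value of compound 3 is (4.4), ranging from (4) to (4.8).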

Compound 3, partition coefficient: 4.54
For compound 3 the middle estimate is 0.14 log units below the measured one, and the stated range covers the measured number.
By their numbers in this assay, from the lowest: compounds 1 and 2 (each within the scatter of the next); then compound 3.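

Compound 1 and compound 2 had shown only that 3-hydroxyphenyl and 2-hydroxyphenyl stand level in this assay. Exchanging the hydroxy group for chloro does move the read-out: 3-chlorophenyl in place of 2-hydroxyphenyl gives (a number 0.81 log units higher from compound 2 to compound 3 (beyond the scatter)), and chloro in place of hydroxy on an aromatic carbon gives a step of the same size (a number 0.81 log units higher from compound 1 to compound 3 (beyond the scatter)). Among these three compounds, then, the read-out follows which group is on the ring. Where a 2-chlorophenyl or a 3-aminophenyl group would stand remains open. Nothing given here explains the step.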